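Bromo for methyl on a chromone sulfoxide series

The compounds below may be only part of what the source reports. "The series", "measured", "known", "first", "only" and "open" are said of these compounds alone.

Three compounds share one core bearing a vinyl methyl sulfoxide arm. In a functional assay on DLD-1 cells (Homo sapiens) for cytotoxicity, with a stated time of 48 h (a higher number here means a weaker inhibitor, a lower number a stronger inhibitor), compound 1 `Cc1ccc2oc(/C=C/[S+](C)[O-])cc(=O)c2c1` gives 7000 nM; compound 2 `COc1ccc2c(=O)cc(/C=C/[S+](C)[O-])oc2c1` gives 7800 nM; compound 3 `Cc1c(/C=C/[S+](C)[O-])oc2ccccc2c1=O` gives 7200 nM. Compound 1 carries the lowest of the three numbers, yet both others sit within the usual scatter of it, so no order among them can be read. Compound 4 `C[S+]([O-])/C=C/c1cc(=O)c2cc(Br)ccc2o1` is not yet measured in this assay; it differs from compound 1 by bromo in place of methyl on an aromatic carbon. For the measured compounds named here, with no measured pair isolating this change, the three known values suggest little movement, and the step from compound 1 is expected to be no change at the digits printed from compound 1 to compound 4 (within the scatter), none beyond the scatter. Compound 4 is therefore estimated at 7000 nM, with a range from 3500 nM to 14000 nM.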

Compound 4, half-maximal inhibitory concentration: 4500 nM
Compound 4: the middle estimate sits 1.6-fold (0.19 log units) above what was measured; the measured number falls inside the stated range.
By their numbers in this assay, from the lowest: compounds 4, 1, 3 and 2 (each within the scatter of the next).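

In this assay, for the compounds shown here, bromo in place of methyl on an aromatic carbon gives a 1.6-fold lower number from compound 1 to compound 4 (0.19 log units; within the scatter) and is the first single change on the shared core that can be read directly. At this carbon, meta to a fused ring and para to a fused ring, the two groups cannot be told apart in this read-out. Nothing shown gives a cause for this result. Still open, from the compounds shown here alone, is whether an amine or a carboxylic acid on this same carbon would move the number beyond the scatter.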